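The source may hold more compounds than are shown below. What is called first, only, known or untested is meant among the compounds shown, and "the series" means these compounds.

Among the two compounds measured in an assay on isolated protein for inhibition of sodium-dependent dopamine transporter (Rattus norvegicus), read by radioligand binding (on this read-out lower numbers stand for stronger inhibition and higher numbers for weaker inhibition), compound 2 `CN1CCC(c2ccc(Cl)cc2)C(C[S+]([O-])CCO)C1` stands with the lowest number, giving 12 nM, while compound 1 `COC(=O)C[S+]([O-])CC1CN(C)CCC1c1ccc(Cl)cc1` gives 231 nM. For the measured compounds named here, the only measured step, a 19-fold lower number from compound 1 to compound 2 (1.28 log units; beyond the scatter), concerns a different part of the molecule than the change now in view. Going by the values given here, compound 3 `COCCSCC1CN(C)CCC1c1ccc(Cl)cc1` differs from compound 2 by a group of 5 heavy atoms (3 carbon, 1 oxygen, 1 sulfur; no ring) in place of a group of 5 heavy atoms (2 carbon, 2 oxygen, 1 sulfur; no ring), on a saturated chain carbon bound to a saturated ring carbon; no measured step bears on this exchange. The expectation for compound 3 is therefore a modest step, a 2.5-fold higher number from compound 2 to compound 3 (0.40 log units; beyond the scatter), leaning toward a higher number, with an estimate of 30 nM and a range from 6 nM to 150 nM.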

Compound 3, inhibition constant: 50 nM
Estimate against measurement, compound 3: 1.7-fold (0.22 log units) below; low and high end bracket the measured number.
By their numbers in this assay, from the lowest: compound 2; then compound 3; then compound 1.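

With (2-methoxyethyl)sulfanyl entering, which has 0 hydrogen-bond donors where the group leaving has 1, this assay shows a 4.2-fold higher number from compound 2 to compound 3 (0.62 log units; beyond the scatter) and also a 4.6-fold lower number from compound 1 to compound 3 (0.66 log units; beyond the scatter) so that compound 3 sits between the two earlier compounds. This position therefore responds to more than the methoxycarbonyl exchange, but the exchange alters the sulfur and the chain end together, and this step cannot separate them. No measured information explains either step. Still open, as far as these compounds go, is how an amine, a carboxylic acid or a longer chain would compare here.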